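The compounds below may be only part of what the source reports. "The series", "measured", "known", "first", "only" and "open" are said of these compounds alone.

Compound 1 `Cc1cc(C)cc(S(=O)(=O)c2c(C(=O)NCC(=O)NCc3ccncc3)[nH]c3ccc(Cl)cc23)c1` stands at the edge of the measured range: in an ADME assay on MT4 cells (Homo sapiens) for cytotoxicity, read by MTT assay (on this read-out higher numbers stand for lower toxicity in this test and lower numbers for higher toxicity in this test), compound 1 gives > 48900 nM, which is a limit of the assay and not a number, as the limit of > 48900 nM in this assay, at which 1 of the 3 values shown sits, records. Compound 2 `Cc1cc(C)cc(S(=O)(=O)c2c(C(=O)NC(C)C(=O)NCc3ccco3)[nH]c3ccc(Cl)cc23)c1` in this assay gives 24200 nM, and compound 3 `Cc1cc(C)cc(S(=O)(=O)c2c(C(=O)NCC(=O)NC(C)c3ccccc3F)[nH]c3ccc(Cl)cc23)c1` gives 23000 nM. Compound 4 `COc1cccc(F)c1CNC(=O)c1[nH]c2ccc(Cl)cc2c1S(=O)(=O)c1cc(C)cc(C)c1` differs from compound 1 by a larger change at the same end of the molecule: 2-fluoro-6-methoxyphenyl in place of ((pyridin-4-yl)methyl)carbamoyl on a saturated chain carbon bound to an amide-type nitrogen. Both measured steps away from compound 1, an at least 2.0-fold lower number from compound 1 to compound 2 (0.30 log units; that floor lies within the scatter) and an at least 2.1-fold lower number from compound 1 to compound 3 (0.32 log units; beyond the scatter), replaced the (pyridin-4-yl)methyl group and lowered the number, so compound 4 is expected to follow them, with an at least 2.0-fold lower number from compound 1 to compound 4 (0.30 log units; that floor lies within the scatter). Compound 4 is therefore estimated at 24000 nM, between 11000 nM and 48900 nM.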

Compound 4, half-maximal cytotoxic concentration: > 49900 nM
Compound 4 ended at the assay's limit; the forecaster's own chance of this, stated with the estimate: 30%; middle value at least 2.0-fold (0.31 log units) from the limit.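

In this assay compound 4 gives > 49900 nM, which is a limit of the assay and not a number. The 2-fluoro-6-methoxybenzyl group gives an at least 2.1-fold higher number from compound 3 to compound 4 (0.33 log units; beyond the scatter) and an at least 2.0-fold higher number from compound 2 to compound 4 (0.31 log units; beyond the scatter), so losing the (pyridin-4-yl)methyl group does not by itself bring the lower number. The step between compound 1 and compound 4 cannot be read, since both values are limits: the limit of > 49900 nM in this assay, at which 1 of the 4 values shown sits.

As far as these compounds go, how far compound 1 and compound 4 lie past their limits stays open. So does whether an amine or a carboxylic acid at this place would also reach the limit.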